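Propyl to isopropyl: expectation for compound 3

A few compounds are considered here, and "the series" means these few. Any claim that something is new, unique, unknown or untested is made for them only; others in the source may bear on it.

Measured so far in a functional assay on A549 cells (Homo sapiens) for cytotoxicity, with a stated time of 48 h; on this read-out higher numbers stand for weaker inhibition and lower numbers for stronger inhibition:
compound 1 `CC(=O)Oc1ccc2oc(/C=C/[S+](C)[O-])cc(=O)c2c1`: 4100 nM
compound 2 `CCCCCOc1ccc2oc(/C=C/[S+](C)[O-])cc(=O)c2c1`: 1600 nM

Within the data shown here, compound 2 has the lower of the two numbers in this assay; its only neighbour is compound 1, and the step of a 2.6-fold lower number from compound 1 to compound 2 (0.41 log units; beyond the scatter) separates them.

Compound 3 `CC(C)CCOc1ccc2oc(/C=C/[S+](C)[O-])cc(=O)c2c1` has not been measured. It differs from compound 2 in one place: isopropyl in place of propyl on a saturated chain carbon, two bonds along the chain from an oxygen on an aromatic ring. The chain keeps its length to the branch point and only the outer part is rearranged.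

Among the measured compounds shown here, the one measured step, a 2.6-fold lower number from compound 1 to compound 2 (0.41 log units; beyond the scatter), concerns a different change, acetyl to pentyl on the oxygen on the aromatic ring, and so bears on this step only loosely: it shows that the group on that oxygen matters, but says nothing about branching within the pentyl chain. For the measured compounds named here, there is no measured pair that varies the shape of an alkyl chain at this position. With no guidance in either direction, the expected step of no change at the digits printed from compound 2 to compound 3 (within the scatter) is taken to lie within the scatter.

Compound 3 is therefore estimated at 1600 nM in this assay, with a range of 700 nM to 3600 nM.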

Compound 3, half-maximal inhibitory concentration: 1000 nM
For compound 3 the middle estimate is 1.6-fold (0.20 log units) above the measured one; the range from low to high includes it.
By their numbers in this assay, from the lowest: compounds 3 and 2 (each within the scatter of the next); then compound 1.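

In this assay, the change of propyl to isopropyl at this place on the chain gives a 1.6-fold lower number from compound 2 to compound 3 (0.20 log units; within the scatter) and so offers the first read on chain shape here: pentyl and isopentyl on this oxygen cannot be told apart. The change from acetyl to isopentyl gives a 4.1-fold lower number from compound 1 to compound 3 (0.61 log units; beyond the scatter) and thus adds a second alkyl group lying beyond the scatter from the acetyl of compound 1, which shows that this separation is not confined to the unbranched pentyl of compound 2. Nothing available accounts for either step.

Still open, going by these compounds, is whether a longer chain such as octyl, a cyclohexyl group, or a chain ending in an amine or a carboxylic acid on this oxygen would stay within the scatter of compound 2 and compound 3. Also open, on these data alone, is whether a free hydroxyl in place of these groups would read closer to the acetyl of compound 1 or to the two alkyl ethers.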